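The source may hold more compounds than are shown below. What is called first, only, known or untested is meant among the compounds shown, and "the series" means these compounds.

Compound 1 `CCOC(=O)C(=O)Nc1cccc(N(C)C)c1C#N` gives 0.2 mg/kg
Compound 2 `CCOC(=O)C(=O)Nc1cccc(OC)c1C#N` gives 5.3 mg/kg
Compound 3 `CCOC(=O)C(=O)Nc1ccc(N(C)C)cc1C#N` gives 1 mg/kg

In a functional assay on the whole organism with Rattus norvegicus as the target (on this read-out lower numbers stand for an effect already at smaller amounts and higher numbers for an effect only at larger amounts of compound), compound 3 stands second highest of the three numbers, with compound 1 lower and compound 2 higher. Compound 4 `CCOC(=O)C(=O)Nc1ccc(N)cc1C#N` carries amino in place of dimethylamino on an aromatic carbon (the two methyl-bearing carbons are gone, the nitrogen stays). Among the compounds with values here, only one measured step also removes dimethylamino (a 27-fold higher number from compound 1 to compound 2 (1.42 log units; beyond the scatter)). That step is large, but methoxy enters there, not amino, so it hints at a direction and says little about size. A more modest rise is therefore expected (a 2.5-fold higher number from compound 3 to compound 4 (0.40 log units; beyond the scatter)). For compound 4 the estimate is 2.5 mg/kg (expected range 0.6 mg/kg to 9 mg/kg).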

Compound 4, dose for half-maximal effect: 1 mg/kg
For compound 4 the middle estimate is 2.5-fold (0.40 log units) above the measured one, within the range that was stated.
By their numbers in this assay, from the lowest: compound 1; then compounds 3 and 4 (each within the scatter of the next); then compound 2.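

In this assay, this position, para to a group of 8 heavy atoms and meta to a cyano group, tolerates the loss of both methyl-bearing carbons: amino in place of dimethylamino gives (no change at the digits printed from compound 3 to compound 4 (within the scatter)). The nitrogen stays and a hydrogen-bond donor enters, yet the read-out does not move. Nothing available here offers a reason for this.

As far as these compounds go, whether this position would accept a group without that nitrogen, such as hydroxyl or a plain hydrogen, remains open. So does the effect of methylamino, which would keep one methyl.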